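The compounds below may be only part of what the source reports. "The series", "measured", "known", "first", "only" and "open" are said of these compounds alone.

Of the compounds shown here, three sharing one core have been tested in a functional assay on NCI-H1975 cells (Homo sapiens) for cytotoxicity, read by CCK-8 assay, with a stated time of 72 h; on this read-out higher numbers stand for weaker inhibition and lower numbers for stronger inhibition. Compound 1 `C=CCn1c(=O)/c(=C\c2cccc(C)c2)[nH]c(=O)/c1=C\c1ccccc1OC` gives 32800 nM. Compound 3 `C=CCn1c(=O)/c(=C\c2ccccc2F)[nH]c(=O)/c1=C\c1ccccc1OC` gives 25100 nM, and the step of a 1.3-fold lower number from compound 1 to compound 3 (0.12 log units; within the scatter) lies within the scatter, so compound 1 and compound 3 sit together at essentially the same level. Compound 2 `C=CCn1c(=O)/c(=C\c2cccc(Br)c2)[nH]c(=O)/c1=C\c1ccccc1OC`, which carries a 3-bromophenyl group at the same position, gives "not active" (no number reported) in this assay, so it shows no measurable inhibition at all.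

The next compound, compound 4 `C=CCn1c(=O)/c(=C\c2cccc(Cl)c2)[nH]c(=O)/c1=C\c1ccccc1OC`, differs from compound 3 in one place: 3-chlorophenyl in place of 2-fluorophenyl on a double-bonded chain carbon bound to an aromatic carbon. Within the data shown here, only one measured step bears on a change at this position, the step from compound 1 to compound 3, and it was within the scatter. The outcome for compound 2 adds a caution: a 3-bromophenyl group gave no activity, and a 3-chlorophenyl group resembles it in where it sits. Taken together, compound 4 is expected to give a number no better than compound 3, with the step of a 2.0-fold higher number from compound 3 to compound 4 (0.30 log units; within the scatter) likely pointing toward weaker inhibition, and a real chance that no number at all is returned. The estimate for compound 4 is therefore 50000 nM, with a range from 20000 nM to 150000 nM.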

Compound 4, half-maximal inhibitory concentration: 5100 nM
The estimate for compound 4 lay 9.8-fold (0.99 log units) above the measured number; the whole stated range lies above it.
By their numbers in this assay, from the lowest: compound 4; then compounds 3 and 1 (each within the scatter of the next).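

In this assay, this position proves sensitive to the group it carries, something the earlier pair, which sat together within the scatter, could not show: 3-chlorophenyl in place of 2-fluorophenyl gives a 4.9-fold lower number from compound 3 to compound 4 (0.69 log units; beyond the scatter), a step beyond the scatter. Chloro in place of methyl on the same aromatic carbon gives a 6.4-fold lower number from compound 1 to compound 4 (0.81 log units; beyond the scatter), so a single group on the ring changes the result even when the rest of the molecule stays the same, although compound 2, with its 3-bromophenyl group, goes against any general rule favouring a halogen here, and no step involving it can be read without a number. Nothing available explains why the chloro compound gives the lower number.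

On these data alone, it remains open whether the gain belongs to chloro alone or would extend to groups such as 3-trifluoromethylphenyl, 3-methoxyphenyl or a phenyl ring carrying an amine or a carboxylic acid. Also unresolved is whether moving the chlorine, as in 2-chlorophenyl or 4-chlorophenyl, would keep the lower number.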